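The source may hold more compounds than are shown below. What is called first, only, known or untested is meant among the compounds shown, and "the series" means these compounds.

In a functional assay on HeLa cells (Homo sapiens) for antiproliferative activity, read by sulforhodamine B assay, with a stated time of 72 h (a lower number here means a stronger inhibitor, a higher number a weaker inhibitor), compound 1 `FC(F)(F)c1ccc(/C=C\c2cc3ccccc3nc2Cl)cc1` gives 4220 nM, while compound 2 `COc1ccc2nc(Cl)c(/C=C\c3ccc(C(F)(F)F)cc3)cc2c1`, with methoxy in place of hydrogen on an aromatic carbon, gives 16200 nM. Compound 2 therefore has the higher of the two numbers and is the weaker inhibitor of the pair.

Compound 3 `COc1ccc2nc(Cl)c(/C=C/c3ccc(C(F)(F)F)cc3)cc2c1` is the next to be considered. Its relation to compound 2 is simple: the two compounds have the same atoms and bonds and differ only in configuration as drawn: 1 of 1 stereo elements differ; a double bond is drawn Z in compound 2 and E in compound 3. Nothing else in the structure changes.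

Going by the values given here, the only measured step, a 3.8-fold higher number from compound 1 to compound 2 (0.58 log units; beyond the scatter), comes from the methoxy replacement, not from a change in configuration. It bears on this question only indirectly, giving a rough scale but no direction. Among the compounds with values here, no measured pair here shows what a change from Z to E does in this assay, so the expectation is loose. Within the data shown here, a step of about modest size is expected, leaning slightly towards a lower number, since compound 2 already stands at 16200 nM, the high end of the numbers so far. The expected change is a 1.6-fold lower number from compound 2 to compound 3 (0.21 log units; within the scatter). Compound 3 is estimated at 10000 nM, with a range of 2500 nM to 40000 nM.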

Compound 3, half-maximal inhibitory concentration: > 50000 nM
Compound 3: no number, only a limit; the forecaster's own chance of this, stated with the estimate: 15%; at least 5.0-fold (0.69 log units) between middle value and limit.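

In this assay, turning the double bond from Z to E gives an at least 3.0-fold higher number from compound 2 to compound 3 (0.48 log units; beyond the scatter), so the direction of this change is now known, which the methoxy step could not show: here the Z compound has the lower number. The step can be assigned to the double bond alone because nothing else separates the pair: the fact that compounds 2 and 3 differ only in the configuration as drawn. For compound 3 there is only a limit and not a number, so the step sets a floor on the size of the change and no more, and the reason lies in this reading: the limit of > 50000 nM in this assay, at which 1 of the 3 values shown sits.

Whether the same change of configuration has the same direction without the methoxy group, on the core of compound 1, remains open, since only the Z form of that compound is shown here. Also open, on these data alone, is how either configuration responds when the trifluoromethyl group gives way to a nitrile or an amine, or when the chlorine gives way to an amine or a carboxylic acid.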